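A few compounds are considered here, and "the series" means these few. Any claim that something is new, unique, unknown or untested is made for them only; others in the source may bear on it.

Compound 1 `COc1ccc(-c2cn(-c3ccc(OC(F)(F)F)cc3)nn2)cc1O` and compound 2 `COc1ccc(-c2cn(-c3ccc(OC(F)(F)F)cc3)nn2)cc1OC` share one core and differ only in a methyl in place of hydrogen on an oxygen on an aromatic ring. In a functional assay on MDA-MB-231 cells (Homo sapiens) for cytotoxicity, read by MTT assay (a higher number here means a weaker inhibitor, a lower number a stronger inhibitor), compound 1 gives only a limit of > 10000 nM. In this assay compound 2 likewise gives only a limit, namely > 1000 nM. The step that the two limits leave unreadable from compound 1 to compound 2 therefore cannot be read, since both of its ends rest on limits, one at the limit of > 10000 nM in this assay, at which 1 of the 2 values shown sits, and the other at the limit of > 1000 nM in this assay, at which 1 of the 2 values shown sits. Compound 2 thus stands nowhere firm on the numbers shown; it is known only to lie past its own limit. Compound 3 `COc1cc(-c2cn(-c3ccc(OC(F)(F)F)cc3)nn2)cc(OC)c1OC` carries, relative to compound 2, (methoxy in place of hydrogen on an aromatic carbon). Going by the values given here, no measured step of readable size bears on this change; the single measured step, a methyl in place of hydrogen on an oxygen on an aromatic ring, is itself unreadable. Among the compounds with values here, what can be expected in this assay is therefore no step that could be stated beyond the scatter, and most probably another limit. For compound 3 the estimate in this assay is 5000 nM, within 1500 nM to 30000 nM. The step that the limit leaves unreadable from compound 2 to compound 3 is expected to be small at best.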

Compound 3, half-maximal inhibitory concentration: > 10000 nM
Compound 3 gave a limit, no number; the forecaster's own chance of this, stated with the estimate: 70%; middle value at least 2.0-fold (0.30 log units) away from the limit.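

In this assay, compound 2 and compound 3 both give only limits, so the step between them, methoxy in place of hydrogen on an aromatic carbon, cannot be read. The compounds shown leave open how strongly compound 1, compound 2 and compound 3 act in this assay, and whether either change on the shared core alters that at all.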